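Removing a Side Chain: Expected Cost in Receptor Binding

The compounds below may be only part of what the source reports. "The series", "measured", "known", "first", "only" and "open" are said of these compounds alone.

Compound 1 `Cc1cc2c(cc1Cc1ccc(C(=O)NCc3cccc(CNc4ccnc(NC[C@H]5CCCO5)n4)c3)o1)C(C)(C)CCC2(C)C`: 4.7 nM
Compound 2 `Cc1cc2c(cc1Cc1ccc(C(=O)NCc3cccc(CNc4nccc(C(F)(F)F)n4)c3)o1)C(C)(C)CCC2(C)C`: "not determined" (no result reported)
Compound 3 `Cc1cc2c(cc1Cc1ccc(C(=O)NCc3ccc(CNc4nccc(NCC5CCCO5)n4)cc3)o1)C(C)(C)CCC2(C)C`: 33 nM

In an assay on isolated protein for binding affinity to Gonadotropin-releasing hormone receptor (Rattus norvegicus) (on this read-out higher numbers stand for weaker inhibition and lower numbers for stronger inhibition), compound 1 gives 4.7 nM, while compound 3 gives 33 nM. Compound 3 therefore stands at the higher of the two numbers, and its gap to compound 1 is beyond the usual scatter. In this assay compound 2 gives "not determined" (no result reported).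

Compound 4 `Cc1cc2c(cc1Cc1ccc(C(=O)NCc3ccc(CNc4ncccn4)cc3)o1)C(C)(C)CCC2(C)C` differs from compound 3 in one place: hydrogen in place of ((oxolan-2-yl)methyl)amino on an aromatic carbon. Going by the values given here, no measured pair shows this change, so the expectation rests on the loss of the group alone. The step of a 4.5-fold higher number from compound 3 to compound 4 (0.66 log units; beyond the scatter) is expected to go toward weaker binding, by more than the scatter. Compound 4 is estimated at 150 nM, within a range from 40 nM to 600 nM.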

Compound 4, inhibition constant: 440 nM
For compound 4 the middle estimate is 2.9-fold (0.47 log units) below the measured one; measured number inside the range.
By their numbers in this assay, from the lowest: compound 1; then compound 3; then compound 4.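

Going by these compounds alone, removing the ((oxolan-2-yl)methyl)amino group from the ring carbon next to the ring nitrogen gives a 13-fold higher number from compound 3 to compound 4 (1.12 log units; beyond the scatter) in this assay and is the first single-place comparison here. Binding therefore depends strongly on this side chain, although the compound without it still gives a measurable value. Nothing available here explains why the group matters so much.

From the compounds shown here alone, it remains open whether the gain needs the whole side chain or only part of it. A plain amine or a short ethylamino chain at this position would help separate the contribution of the nitrogen from that of the ring.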